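The compounds below may be only part of what the source reports. "The series", "measured", "known", "first", "only" and "open" are said of these compounds alone.

Working notes on the thiosemicarbazone series in a functional assay on A-375 cells (Homo sapiens) for cytotoxicity, read by MTT assay, with a stated time of 72 h, tested at 100 uM; a lower number here means less inhibition of growth, a higher number more inhibition of growth at the concentration tested. Compound 3 `Cc1ccnc(/C(N)=N/NC(=S)N2CCCCC2)c1` gives 85.6%. Among the three measured compounds it holds the lowest number, but each of its gaps is within the scatter: compound 2 `N/C(=N\NC(=S)N1CCCC1)c1ccccn1` gives 87.8%, and compound 1 `Cc1ccnc(/C(N)=N/NC(=S)N2CCOCC2)c1` gives 90.6%. For the measured compounds named here, the only one-place step measured, a number 5 percentage points lower from compound 1 to compound 3 (within the scatter), is a change of the ring on the thiocarbonyl carbon and stays within the scatter.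

Compound 4 `Cc1ccnc(/C(N)=N/NC(=S)N2CCCC2)c1` differs from compound 3 by pyrrolidin-1-yl in place of piperidin-1-yl on a thiocarbonyl carbon. Compound 2 carries the same pyrrolidin-1-yl on its thiocarbonyl carbon and sits at a number within the scatter of compound 3, and the ring change a number 5 percentage points lower from compound 1 to compound 3 (within the scatter) on this carbon produced no step beyond the scatter. The ring swap in compound 4 is therefore expected to give no step beyond the scatter in this assay, with a number 1.4 percentage points higher from compound 3 to compound 4 (within the scatter). Compound 4 is estimated at 87%, expected between 79% and 94%.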

Compound 4, percent growth inhibition at one concentration: 88.8%
Beside the measured number, compound 4's estimate is 1.8 percentage points below it; low and high end bracket the measured number.
By their numbers in this assay, from the lowest: compounds 3, 2, 4 and 1 (each within the scatter of the next).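

On the thiocarbonyl carbon, pyrrolidin-1-yl now stands on the same core as piperidin-1-yl and morpholin-4-yl, and in this assay the ring swaps give a number 3.2 percentage points higher from compound 3 to compound 4 (within the scatter) and a number 1.8 percentage points lower from compound 1 to compound 4 (within the scatter) with no step beyond the scatter among the three rings. For the compounds shown here, the first one-place reading on an aromatic carbon, methyl in place of hydrogen, gives a number 1 percentage points higher from compound 2 to compound 4 (within the scatter) and so also shows no step beyond the scatter. No available evidence bears on these results.

As far as these compounds go, it remains open whether an open-chain amine such as dimethylamino or a piperazin-1-yl ring on the thiocarbonyl carbon, or a carboxylic acid in place of methyl on the aromatic carbon, would give a step beyond the scatter. From the compounds shown here alone, with all four compounds read at one concentration, any separation among them at lower concentrations also remains open.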